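Replacing chloro with hydrogen on compound 2

A few compounds are considered here, and "the series" means these few. Any claim that something is new, unique, unknown or untested is made for them only; others in the source may bear on it.

In an ADME assay on J774 cells (Mus musculus) for cytotoxicity, read by fluorescence and resazurin assay, with a stated time of 24 h (on this read-out lower numbers stand for higher toxicity in this test and higher numbers for lower toxicity in this test), compound 1 `O=[N+]([O-])c1ccc(S(=O)(=O)Nc2nccc3ccccc23)cc1` gives 41300 nM as its half-maximal cytotoxic concentration.

Compound 2 `O=S(=O)(Nc1nccc2ccccc12)c1ccc(Cl)cc1` stands at >= 300000 nM in this assay and this figure is a limit of the assay, not a number. Within the data shown here, it is the only position compound 2 has on the scale (the limit of >= 300000 nM in this assay, at which 1 of the 2 values shown sits).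

Compound 3 `O=S(=O)(Nc1nccc2ccccc12)c1ccccc1` carries hydrogen in place of chloro on an aromatic carbon, para to a large group (hydrogen in place of chloro on an aromatic carbon).

Among the measured compounds shown here, only one measured step bears on this change, namely an at least 7.2-fold higher number from compound 1 to compound 2 (0.86 log units; beyond the scatter) and it lies beyond the scatter, but it replaces nitro rather than hydrogen. For the measured compounds named here, with that step as the sole guide, a modest move towards lower numbers is expected in this assay, and none beyond the scatter remains possible.

The estimated step is an at least 1.6-fold lower number from compound 2 to compound 3 (0.22 log units; that floor lies within the scatter) in this expectation.

Compound 3 is expected at 180000 nM with an estimated range from 70000 nM to 350000 nM in this assay.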

Compound 3, half-maximal cytotoxic concentration: >= 300000 nM
Compound 3: a limit, no number; the forecaster's own chance of this, stated with the estimate: 45%; middle value at least 1.6-fold (0.22 log units) from the limit.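

In this assay, compound 3 joins compound 2 at a limit of the assay, not a number: the limit of >= 300000 nM in this assay, at which 2 of the 3 values shown sit. The step between these two compounds cannot be read, so this result does not separate chloro from hydrogen at this position. Hydrogen in place of nitro gives an at least 7.2-fold higher number from compound 1 to compound 3 (0.86 log units; beyond the scatter), so the higher number does not require chloro, and nitro is the one group of the three that gives a measured number.

On these data alone, how far chloro and hydrogen lie beyond the limit remains open. So does whether the lower number belongs to nitro alone or would also appear with another group at this place, such as an amine or a carboxylic acid.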